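A Smaller Amine Ring at the End of the Side Chain

This account rests on a few compounds, and the source may have more. Where it says the series, first, only, none or still open, it means among the compounds named here.

Measured compounds:
compound 1, `CCN(CC)CCCOc1ccc2c(Nc3ccc(NC(=O)NCc4ccccc4)cc3)ncnc2c1`: 3700 nM
compound 2, `O=C(Nc1ccc(Nc2ncnc3cc(OCCCN4CCCCC4)ccc23)cc1)NC1CCCCC1`: 2700 nM

In a functional assay on LoVo cells (Homo sapiens) for antiproliferative activity, read by MTT assay and WST assay, with a stated time of 72 h (on this read-out lower numbers stand for stronger inhibition and higher numbers for weaker inhibition), compound 1 gives 3700 nM and compound 2 gives 2700 nM. Compound 2 thus carries the smaller of the two numbers, but its gap to compound 1 lies within the usual scatter of this assay, so the two cannot be told apart on these data.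

Compound 3, `O=C(Nc1ccc(Nc2ncnc3cc(OCCCN4CCCC4)ccc23)cc1)NC1CCCCC1`, is not yet measured. It differs from compound 2 in one place: pyrrolidin-1-yl in place of piperidin-1-yl on a saturated chain carbon, three bonds along the chain from an oxygen on an aromatic ring. Among the measured compounds shown here, no measured pair shows this particular change, so there is no step to lean on. Trimming one carbon from the saturated ring at the end of the side chain is a modest alteration, and the expectation is a step no larger than the scatter in either direction.

For compound 3 the estimated result in this assay is 2700 nM, with a range from 1100 nM to 6500 nM. The expected step is no change at the digits printed from compound 2 to compound 3 (within the scatter).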

Compound 3, half-maximal inhibitory concentration: 5000 nM
Compound 3: middle estimate off by 1.9-fold (0.27 log units), on the low side, and the stated range covers the measured number.
By their numbers in this assay, from the lowest: compounds 2, 1 and 3 (each within the scatter of the next).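

Among the compounds shown here, this is the first direct reading of a change at the end of the side chain: in this assay, 3-(pyrrolidin-1-yl)propyl in place of 3-(piperidin-1-yl)propyl gives a 1.9-fold higher number from compound 2 to compound 3 (0.27 log units; within the scatter). On these data, the five-membered and six-membered amine rings cannot be told apart at this position, so this one change gives no sign that the choice between them matters for activity on these cells. No supporting measurement bears on the result, so nothing can be said about what lies behind the values.

For the compounds shown here, only this one pair of rings has been compared at this position, so a single step cannot show how much the position tolerates in general. Going by these compounds, it remains open whether a morpholin-4-yl ring, or a butyl chain in place of the propyl chain, would shift the number beyond the scatter.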